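Halogen position on the benzylic arene and T-cell inhibition

A few compounds are considered here, and "the series" means these few. Any claim that something is new, unique, unknown or untested is made for them only; others in the source may bear on it.

Compound 1 `COc1cc(-c2nnc(SCc3ccc(Cl)cc3)o2)ccc1O`: 11100 nM
Compound 2 `COc1cc(-c2nnc(SCc3c(F)cccc3F)o2)ccc1O`: 10100 nM
Compound 3 `COc1cc(-c2nnc(SCc3ccccc3Cl)o2)ccc1O`: 8430 nM

In a functional assay on cells (T-cell, Mus musculus, strain BALB/c) for inhibition, read by MTT assay, with stated times of 24 h and 72 h (a higher number here means a weaker inhibitor, a lower number a stronger inhibitor), compound 3 gives the lowest of the three numbers, though its neighbours lie close: a 1.3-fold lower number from compound 1 to compound 3 (0.12 log units; within the scatter) and a 1.2-fold lower number from compound 2 to compound 3 (0.08 log units; within the scatter) are both within the scatter, so the three compounds cannot be ordered. Compound 4 `COc1cc(-c2nnc(SCc3ccc(Br)cc3)o2)ccc1O` differs from compound 3 as follows: 4-bromophenyl in place of 2-chlorophenyl on a saturated chain carbon bound to a sulfur. The step from 4-chlorophenyl to 2-chlorophenyl, a 1.3-fold lower number from compound 1 to compound 3 (0.12 log units; within the scatter), is the closest measured relative of this change, and it was within the scatter, as was a 1.1-fold lower number from compound 1 to compound 2 (0.04 log units; within the scatter). For the measured compounds named here, no step here moves the number beyond the scatter, so for compound 4 a step within the scatter is expected, a 1.2-fold higher number from compound 3 to compound 4 (0.07 log units; within the scatter). Compound 4 is therefore estimated at 9800 nM, with a range of 4500 nM to 21000 nM.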

Compound 4, half-maximal inhibitory concentration: 8830 nM
The estimate for compound 4 lay 1.1-fold (0.05 log units) above the measured number; measured number inside the range.
By their numbers in this assay, from the lowest: compounds 3, 4, 2 and 1 (each within the scatter of the next).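

In this assay, the exchange of bromo for chloro on an aromatic carbon, a 1.3-fold lower number from compound 1 to compound 4 (0.10 log units; within the scatter), changes the halogen alone, and it stays within the scatter. The other two steps, a 1.0-fold higher number from compound 3 to compound 4 (0.02 log units; within the scatter) and a 1.1-fold lower number from compound 2 to compound 4 (0.06 log units; within the scatter), are also within the scatter, so no group yet placed on a saturated chain carbon bound to a sulfur separates from the rest. No measured evidence bears on this result.

The compounds shown leave open whether an unsubstituted phenyl, an amine, a carboxylic acid or a longer chain at this place would move the number beyond the scatter.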